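Oxime ether chain length and breast-cancer cell growth inhibition

This account rests on a few compounds, and the source may have more. Where it says the series, first, only, none or still open, it means among the compounds named here.

Measured compounds:
compound 1 `CCOC(=O)CCO/N=C(/c1ccc(OC)c(OC)c1OC)c1cccc2ccccc12` – 15200 nM
compound 2 `COc1ccc(/C(=N/O)c2cccc3ccccc23)c(OC)c1OC` – 2500 nM

In a functional assay on MDA-MB-231 cells (Homo sapiens) for inhibition, read by sulforhodamine B assay, with a stated time of 48 h (on this read-out higher numbers stand for weaker inhibition and lower numbers for stronger inhibition), compound 2 holds the lowest of the two numbers; its nearest neighbour, compound 1, sits a 6.1-fold lower number from compound 1 to compound 2 (0.78 log units; beyond the scatter) away. Compound 3 `CCOC(=O)CO/N=C(/c1ccc(OC)c(OC)c1OC)c1cccc2ccccc12` differs from compound 2 by (ethoxycarbonyl)methyl in place of hydrogen on an oxygen. For the measured compounds named here, the one bearing step, a 6.1-fold lower number from compound 1 to compound 2 (0.78 log units; beyond the scatter), accompanied the loss of a longer chain of the same kind; compound 3 reinstates a shorter one. A higher number is therefore expected for compound 3, a step of a 3.6-fold higher number from compound 2 to compound 3 (0.56 log units; beyond the scatter), giving an estimated 9000 nM within 3000 nM to 27000 nM.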

Compound 3, half-maximal inhibitory concentration: 16400 nM
Beside the measured number, compound 3's estimate is 1.8-fold (0.26 log units) below it; low and high end bracket the measured number.
By their numbers in this assay, from the lowest: compound 2; then compounds 1 and 3 (each within the scatter of the next).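

In this assay, (ethoxycarbonyl)methyl in place of hydrogen on the oxygen also gives a weaker result, with a 6.6-fold higher number from compound 2 to compound 3 (0.82 log units; beyond the scatter), so this step is not confined to the longer chain of compound 1. Shortening the chain does not separate the two esters, with a 1.1-fold higher number from compound 1 to compound 3 (0.03 log units; within the scatter), and among these compounds only the hydroxy compound 2 stands apart. Nothing available explains this result. On these data alone, whether a carboxylic acid in place of the ethyl ester, an amine at the chain end or a plain methyl group on the oxygen would stay near compound 2 remains open.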